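Taking the chlorine off a phthalazine hydrazone

The source may hold more compounds than are shown below. What is called first, only, known or untested is meant among the compounds shown, and "the series" means these compounds.

Of the compounds shown here, three sharing the same phthalazine-derived core have been measured for their ability to slow the growth of a human cancer cell line. The read-out is a functional assay on SF-268 cells (Homo sapiens) for antiproliferative activity, read by sulforhodamine B assay, with a stated time of 72 h; a higher number here means a weaker inhibitor, a lower number a stronger inhibitor. Compound 1, `Clc1ccc(C(/C=C/c2ccccc2)=N\Nc2nncc3ccccc23)cc1`, gives 6.3 nM, the lowest of the three numbers. Compound 2, `NC(=S)NNc1nncc2ccccc12`, gives 17 nM, a result that sits beyond the usual scatter from compound 1. Compound 3, `O=S(=O)(Nc1ccccn1)c1ccc(Nc2nncc3ccccc23)cc1`, gives 25 nM, the furthest of the three from compound 1, again beyond the scatter. On these numbers compound 1 stands as the strongest inhibitor of the set.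

The next compound, compound 4, is `C(=C/c1ccccc1)\C(=N\Nc1nncc2ccccc12)c1ccccc1`. It differs from compound 1 in one place: hydrogen in place of chloro on an aromatic carbon. Cut one bond further out, the change reads 4-chlorophenyl to phenyl.

Going by the values given here, no pair of measured compounds differing in only one place is available, so the size of this step must be guessed from the change itself. A modest loss of potency is expected, with the step of a 2.4-fold higher number from compound 1 to compound 4 (0.38 log units; beyond the scatter) likely falling at or a little beyond the scatter. Compound 4 is therefore estimated at 15 nM, within a range from 5 nM to 50 nM.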

Compound 4, half-maximal inhibitory concentration: 3.2 nM
Compound 4: the middle estimate sits 4.7-fold (0.67 log units) above what was measured, and the stated range ends above it.
By their numbers in this assay, from the lowest: compounds 4 and 1 (each within the scatter of the next); then compounds 2 and 3 (each within the scatter of the next).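

In this assay, replacing the chloro of compound 1 with hydrogen on the aromatic ring gives a 2.0-fold lower number from compound 1 to compound 4 (0.29 log units; within the scatter), so the 4-chlorophenyl and the phenyl versions cannot be told apart in this measurement. The earlier compounds shown here said nothing about this position, since none of them forms a one-place pair with another, and this first pair shows that the chlorine is not needed for the activity seen in compound 1. Nothing available explains why the two compounds match, and no supporting data on this change are at hand.

On these data alone, only chloro and hydrogen have been seen at this position, so it remains open whether a methoxy group, an amine or a carboxylic acid on the same carbon would leave the number in the same place or shift it well beyond the scatter. As far as these compounds go, it is also open whether a fluorine or a methyl group on the other phenyl ring of compound 4 would be accepted as readily as this change was.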